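Hydroxypropyl in Place of Benzyl on the Core of Compound 2

This account rests on a few compounds, and the source may have more. Where it says the series, first, only, none or still open, it means among the compounds named here.

Compound 1 `c1ccc(CSc2nc(-c3cc4ccccc4[nH]3)nn2Cc2ccccc2)cc1`: 17.9 ug/mL
Compound 2 `c1ccc(CSc2nc(-c3cc4ccccc4[nH]3)n(Cc3ccccc3)n2)cc1`: 16.3 ug/mL
Compound 3 `S=c1nc(-c2cc3ccccc3[nH]2)[nH][nH]1`: 15.9 ug/mL

In a functional assay on HepG2 cells (Homo sapiens) for antiproliferative activity, read by sulforhodamine B assay, with a stated time of 48 h (on this read-out lower numbers stand for stronger inhibition and higher numbers for weaker inhibition), compound 2 gives 16.3 ug/mL, the second highest of the three numbers. Compound 3 gives 15.9 ug/mL, within the scatter of compound 2. Compound 1 gives 17.9 ug/mL, also within the scatter of compound 2, so the three measured compounds cannot be separated on this read-out. Compound 4 `OCCCn1nc(SCc2ccccc2)nc1-c1cc2ccccc2[nH]1` differs from compound 2 by 2-hydroxyethyl in place of phenyl on a saturated chain carbon bound to an aromatic nitrogen. Among the compounds with values here, no step between measured compounds is available to guide the size of this change, and the three numbers already known all sit together, so the step of a 1.1-fold higher number from compound 2 to compound 4 (0.04 log units; within the scatter) is expected to stay within the scatter in either direction. Compound 4 is estimated at 18 ug/mL, with a range from 9 ug/mL to 36 ug/mL.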

Compound 4, half-maximal inhibitory concentration: 11.5 ug/mL
Compound 4: the middle estimate sits 1.6-fold (0.19 log units) above what was measured; low and high end bracket the measured number.
By their numbers in this assay, from the lowest: compounds 4, 3, 2 and 1 (each within the scatter of the next).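

Exchanging benzyl for 3-hydroxypropyl, with the change on a saturated chain carbon bound to an aromatic nitrogen, gives in this assay a 1.4-fold lower number from compound 2 to compound 4 (0.15 log units; within the scatter), a step within the scatter. The position therefore tolerates the loss of the aromatic ring and the entry of a hydrogen-bond donor without a shift that can be told from the scatter. No evidence at hand bears on this result. Going by these compounds, whether an amine, a carboxylic acid or a longer chain at this place would move the number beyond the scatter remains open.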